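This account rests on a few compounds, and the source may have more. Where it says the series, first, only, none or still open, it means among the compounds named here.

Compound 1 `CCOC(=O)c1c(-c2ccc(OC)c(OC)c2)csc1N(C)C` and compound 2 `COc1ccc(-c2csc(N)c2C(=O)Oc2ccccc2)cc1OC` share one core. In an assay on isolated protein for inhibition of protein kinase C zeta type (Homo sapiens), with stated times of 1 h and 2.5 min, tested at 30 uM (on this read-out lower numbers stand for less inhibition and higher numbers for more inhibition at the one concentration tested (going by the name of the read-out)), compound 1 gives 60%, and compound 2 gives 48%, the lower of the two numbers, with the gap to compound 1 lying beyond the usual scatter. Compound 3 `CCNC(=O)c1c(-c2ccc(OC)c(OC)c2)csc1N` differs from compound 2 in a single place: ethylamino in place of phenoxy on a carbonyl carbon. Among the compounds with values here, no measured pair shows a change of this kind, so the direction of any step is uncertain, and the expected change is small or none beyond the scatter. Compound 3 is expected to give about 50%, with a likely range from 25% to 75%. That estimate means an expected step of a number 2 percentage points higher from compound 2 to compound 3 (within the scatter).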

Compound 3, a percentage reported as inhibition, at one concentration (the size of the read-out at that concentration, not a potency): 50%
The estimate for compound 3 equals the measured number at the digits printed, and the stated range covers the measured number.
By their numbers in this assay, from the lowest: compounds 2, 3 and 1 (each within the scatter of the next, the first and the last beyond it).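

In this assay, putting ethylamino in place of phenoxy on a carbonyl carbon gives a number 2 percentage points higher from compound 2 to compound 3 (within the scatter). The read-out therefore does not separate the two groups at this position, although the change removes an aromatic ring and adds a hydrogen-bond donor. Nothing available explains why the two groups read alike. Going by these compounds, whether a carboxylic acid or a longer chain such as butylamino on the same carbonyl carbon would also read alike remains open. A single tested concentration also leaves open whether compound 2 and compound 3 differ in potency.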